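The source may hold more compounds than are shown below. What is called first, only, known or untested is meant among the compounds shown, and "the series" means these compounds.

Measured compounds:
compound 1 `C[C@H](c1ccc(C(=O)NCCC(=O)O)cc1)N1C(=O)C(c2ccc(F)cc2)=N[C@]12CC[C@@H](C(C)(C)C)CC2` — 85 nM in an assay on CHO cells for displacement of a labelled ligand from Glucagon receptor (Homo sapiens), read by scintillation counting, with a stated time of 60 min; a higher number here means a weaker inhibitor, a lower number a stronger inhibitor
compound 2 `CC1(CC[C@H](c2ccc(C(=O)NCc3nn[nH]n3)cc2)N2C(=O)C(c3cc(Cl)cc(Cl)c3)=N[C@]23CC[C@@H](C(C)(C)C)CC3)CC1` — 17 nM in this assay

Compound 1 gives the higher of the two numbers: in this assay compound 1 shows 85 nM, while compound 2 shows 17 nM, a gap that lies beyond the usual scatter. Among the measured compounds shown here, compound 2 differs from compound 1 in more than one place, so no single step between them can be drawn from these two values alone.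

Compound 3 `C[C@H](c1ccc(C(=O)NCCC(=O)O)cc1)N1C(=O)C(c2cccc(OC(F)(F)F)c2)=N[C@]12CC[C@@H](C(C)(C)C)CC2` has not yet been measured. It differs from compound 1 in one place: 3-(trifluoromethoxy)phenyl in place of 4-fluorophenyl on a carbon with a double bond to nitrogen. For the measured compounds named here, no step between measured compounds isolates this change, so the expectation rests on the value of compound 1 85 nM and on a modest shift that may not exceed the scatter. The step from compound 1 to compound 3 is estimated as a 1.4-fold lower number from compound 1 to compound 3 (0.15 log units; within the scatter). Compound 3 is expected to give about 60 nM, within a range from 20 nM to 180 nM.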

Compound 3, half-maximal inhibitory concentration: 330 nM
Estimate against measurement, compound 3: 5.5-fold (0.74 log units) below; measured number above the stated range.
By their numbers in this assay, from the lowest: compound 2; then compound 1; then compound 3.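

In this assay, 3-(trifluoromethoxy)phenyl in place of 4-fluorophenyl on the carbon with a double bond to nitrogen gives a 3.9-fold higher number from compound 1 to compound 3 (0.59 log units; beyond the scatter). Among the compounds shown here, this is the first change that can be read on its own, and it shows that, with the rest of compound 1 held fixed, the number responds to what this carbon carries, and that this larger group does not improve it. The step swaps the substituent and its place on the phenyl ring together, and no measurement at hand explains the rise.

The compounds shown leave open how 3-fluorophenyl or 4-(trifluoromethoxy)phenyl would read at this carbon, which would separate the group from where it stands on the ring. Also open, going by these compounds, is whether the step would hold with a sulfonic acid in place of the carboxylic acid.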